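A methyl cap on a hydroxyethyl side chain

The source may report more compounds than this note shows. Statements on the series, on what has been measured and on what is new or still open speak of the compounds shown alone.

Compound 1 `COc1cc(/C=C/C(=O)/C=C(/C=C/c2ccc(O)c(OC)c2)NCCO)ccc1O` gives (> 100000 nM)
Compound 2 `COc1cc(/C=C/C2=CC(=O)CC(c3ccc(O)c(OC)c3)N2CCCO)ccc1O` gives (> 100000 nM)
Compound 3 `O=C(/C=C(/C=C/c1ccc(O)cc1)NCCCO)/C=C/c1ccc(O)cc1` gives (54100 nM)

All three were tested in a functional assay on HepG2 cells (Homo sapiens) for cytotoxicity, read by MTT assay, with a stated time of 48 h; on this read-out higher numbers stand for weaker inhibition and lower numbers for stronger inhibition. Compound 1 stands at a limit of the assay (> 100000 nM), not at a number. Compound 2 also stands at a limit (> 100000 nM). This shared ceiling is the limit of > 100000 nM in this assay, at which 2 of the 3 values shown sit. Only compound 3 has a true number (54100 nM).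

Compound 4 `COCCNC(=C\C(=O)/C=C/c1ccc(O)c(OC)c1)/C=C/c1ccc(O)c(OC)c1` differs from compound 1 by methyl in place of hydrogen on an oxygen on a saturated carbon. This turns 2-hydroxyethyl into 2-methoxyethyl. Going by the values given here, no measured pair shows this change, so no step beyond the scatter is expected in this assay. The estimated step is a number no higher from compound 1 to compound 4 (the limit leaves the size open). For compound 4 the expected value is 100000 nM, with an estimated range from 45000 nM to 220000 nM.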

Compound 4, half-maximal inhibitory concentration: > 100000 nM
Compound 4: only a limit was reported (the forecaster's own chance of this, stated with the estimate: 60%); the middle value sits exactly at the limit.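

Compound 1 and compound 4 both sit at a limit rather than at a number, so no step can be read between them: the limit of > 100000 nM in this assay, at which 3 of the 4 values shown sit.

As far as these compounds go, whether 2-methoxyethyl in place of 2-hydroxyethyl changes the result in this assay stays open.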